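The compounds below may be only part of what the source reports. "The series", "measured", "known", "first", "only" and "open" are said of these compounds alone.

Working notes on the series.

Compound 1 `CN1CCN(c2ccc(S(=O)(=O)Oc3cccc(Br)c3)cc2)C1=O` gives 1500 nM in a functional assay on MCF7 cells (Homo sapiens) for antiproliferative activity, read by sulforhodamine B assay, with a stated time of 48 h; a higher number here means a weaker inhibitor, a lower number a stronger inhibitor. Compound 2 `CN1CCN(c2ccc(S(=O)(=O)Oc3cccc(I)c3)cc2)C1=O` gives 560 nM in this assay, so the step of a 2.7-fold lower number from compound 1 to compound 2 (0.43 log units; beyond the scatter) is modest. Compound 3 `CN1CCN(c2ccc(S(=O)(=O)Oc3ccc(Cl)cc3)cc2)C1=O` reaches only the limit of this assay, reported as > 100000 nM, not a number. The steps of an at least 66-fold higher number from compound 1 to compound 3 (1.82 log units; beyond the scatter) and an at least 170-fold higher number from compound 2 to compound 3 (2.25 log units; beyond the scatter) are therefore both large and point to a weaker inhibitor, consistent with the limit of > 100000 nM in this assay, at which 1 of the 3 values shown sits.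

The next compound, compound 4 `CCCN1CCN(c2ccc(S(=O)(=O)Oc3ccc(Cl)cc3)cc2)C1=O`, is not yet measured. Its change from compound 3 is ethyl in place of hydrogen on a saturated chain carbon bound to an amide-type nitrogen in a ring. None of the three measured steps touches this part of the core: each of them alters the aryl ring on oxygen, while the methyl on the amide-type nitrogen in the ring is the same in compound 1, compound 2 and compound 3. Going by the values given here, no measured step therefore bears directly on the move from methyl to propyl, and no basis is available for expecting a shift beyond the scatter in either direction in this assay. Since compound 3 sits at the limit, the most likely outcome for compound 4 is again a limit. Compound 4 is estimated at 100000 nM, with a range from 30000 nM to 300000 nM. The expected step is a number no higher from compound 3 to compound 4 (the limit leaves the size open).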

Compound 4, half-maximal inhibitory concentration: 18000 nM
Beside the measured number, compound 4's estimate is 5.6-fold (0.74 log units) above it; the measured number lies below the stated range.
By their numbers in this assay, from the lowest: compound 2; then compound 1; then compound 4. At a limit, above all of these: compound 3.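

Going by these compounds alone, the step, an at least 5.5-fold lower number from compound 3 to compound 4 (0.74 log units; beyond the scatter), is the first in this assay to show that the group on the amide-type nitrogen in the ring also moves the number, since every earlier step altered only the aryl ring on oxygen. With the 4-chlorophenyl group held constant, the change from methyl to propyl is enough to give a measured number in place of a limit, so the aryl ring on oxygen is not the only part of the core that matters in this series. Compound 3 stands at a limit and not at a number, so the step gives only a lower bound on the size of this change: the limit of > 100000 nM in this assay, at which 1 of the 4 values shown sits.

Going by these compounds, a single pair carries this change, so it remains open whether propyl in place of methyl would also lower the number with the 3-bromophenyl group of compound 1 or the 3-iodophenyl group of compound 2. Also open, on these data alone, is how the number would respond on that nitrogen to a longer chain such as butyl, a branched chain such as isopropyl, or a propyl chain ending in an amine or a carboxylic acid.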